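Methyl on the hydroxy oxygen of compound 1

This account rests on a few compounds, and the source may have more. Where it says the series, first, only, none or still open, it means among the compounds named here.

compound 1 `O=C(NCCCNc1cc(-c2cn(-c3ccccc3)nc2-c2cccc(O)c2)ccn1)Nc1ccc(F)cc1` gives > 14200 nM (a limit)
compound 2 `O=C(NCCCNc1cc(-c2cn(-c3ccccc3)nc2-c2cccc(O)c2)ccn1)Nc1cccc(C(F)(F)F)c1` gives > 14500 nM (a limit)

In a functional assay on K562 cells (Homo sapiens) for antiproliferative activity, read by sulforhodamine B assay, with a stated time of 48 h (a lower number here means a stronger inhibitor of growth, a higher number a weaker inhibitor of growth), compound 1 stands only at a limit (> 14200 nM), not at a number. Compound 2 likewise stands only at a limit (> 14500 nM).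

Compound 3 `COc1cccc(-c2nn(-c3ccccc3)cc2-c2ccnc(NCCCNC(=O)Nc3ccc(F)cc3)c2)c1` departs from compound 1 in one place: methyl in place of hydrogen on an oxygen on an aromatic ring, which reads as 3-hydroxyphenyl to 3-methoxyphenyl. Within the data shown here, no measured step touches that place. Among the measured compounds shown here, the only step available, a step that the two limits leave unreadable from compound 1 to compound 2, concerns an amide-type nitrogen and offers no size to carry over. A step beyond the scatter in this assay is therefore not expected, and no direction can be argued from these data. The expected step is (an at least 1.0-fold lower number from compound 1 to compound 3 (0.00 log units; that floor lies within the scatter)). For compound 3 the estimated value is 14000 nM (expected range 5000 nM to 30000 nM), quite possibly reported only as a limit.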

Compound 3, concentration for total growth inhibition: > 37000 nM
Compound 3 gave a limit, no number; the forecaster's own chance of this, stated with the estimate: 70%; middle value at least 2.6-fold (0.42 log units) away from the limit.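

Compound 1 and compound 3 each stand only at a limit, and the step between them cannot be read, in size or in direction. The compounds shown leave open how 3-hydroxyphenyl and 3-methoxyphenyl compare, as none of them gives a number in this assay.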